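The compounds below may be only part of what the source reports. "The series", "measured", "known", "first", "only" and "open" are said of these compounds alone.

In an assay on microsomes from intestine for inhibition of acyl-CoA:cholesterol acyltransferase (Oryctolagus cuniculus) (a lower number here means a stronger inhibitor, a higher number a weaker inhibitor), compound 1 `CC(C)c1cccc(C(C)C)c1OC(=O)NC(=O)OCCCc1ccccc1` gives 660 nM and compound 2 `CCCCCCCCCCCOC(=O)NC(=O)Oc1c(C(C)C)cccc1C(C)C` gives 140 nM; compound 2 thus holds the lowest of the two numbers. Among the measured compounds shown here, the only measured step, a 4.7-fold lower number from compound 1 to compound 2 (0.67 log units; beyond the scatter), came from octyl in place of phenyl on the saturated chain. Compound 3 `CCCCCCCCCCCCCOC(=O)NC(=O)Oc1c(C(C)C)cccc1C(C)C` carries ethyl in place of hydrogen on a saturated chain carbon, ten or more bonds along the chain from an oxygen next to a carbonyl group, a further lengthening of the same chain. For the measured compounds named here, only the step into compound 2 bears on this, and it was modest; a smaller step in this assay is therefore expected, either toward a lower number or none beyond the scatter. The estimate for compound 3 is 110 nM, range 50 nM to 250 nM, an expected step of a 1.3-fold lower number from compound 2 to compound 3 (0.10 log units; within the scatter).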

Compound 3, half-maximal inhibitory concentration: 9 nM
Compound 3: middle estimate off by 12-fold (1.09 log units), on the high side; measured number below the stated range.
By their numbers in this assay, from the lowest: compound 3; then compound 2; then compound 1.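

In this assay, ethyl in place of hydrogen on a saturated chain carbon, ten or more bonds along the chain from an oxygen next to a carbonyl group, gives a 16-fold lower number from compound 2 to compound 3 (1.19 log units; beyond the scatter) and shows that this position still moves the number by a large step, where the earlier step was modest. Decyl in place of phenyl gives a 73-fold lower number from compound 1 to compound 3 (1.87 log units; beyond the scatter) on the shared core. Nothing at hand explains the size of these steps. Open, as far as these compounds go, is whether a longer chain lowers the number further or reverses the trend. Also open, from the compounds shown here alone, is how a branched chain or a terminal carboxylic acid on this chain would read.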